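A few compounds are considered here, and "the series" means these few. Any claim that something is new, unique, unknown or untested is made for them only; others in the source may bear on it.

Series notes, aryl sulfonyl set. In an assay on isolated protein for displacement of a labelled ligand from metabotropic glutamate receptor 5 (Homo sapiens), with a stated time of 60 min, tested at 1 uM (a higher number here means more inhibition at the concentration tested (going by the name of the read-out), a lower number less inhibition), compound 1 `CCOC(=O)C1CCN(c2c(S(=O)(=O)c3ccccc3)cnc3ccccc23)CC1` gives 33%. Compound 2 `Cc1ccc2ncc(S(=O)(=O)c3ccc(F)cc3)c(N3CCC(C)CC3)c2c1` gives 90% in this assay. Compound 3 `Cc1ccc(S(=O)(=O)c2cnc3cc(Cl)ccc3c2N2CCC(C)CC2)cc1F` gives 85% in this assay, which is the second highest of the three numbers: its nearest neighbour is compound 2, whose value sits within the scatter of it, while its furthest is compound 1, whose value lies beyond the scatter below it. Among the measured compounds shown here, no single-change pair among the measured compounds is available, so no measured step size guides the next move.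

Compound 4 `CC1CCN(c2c(S(=O)(=O)c3ccc(F)c(Cl)c3)cnc3cc(Cl)ccc23)CC1` differs from compound 3 by 3-chloro-4-fluorophenyl in place of 3-fluoro-4-methylphenyl on a sulfonyl sulfur. For the measured compounds named here, the two aryl groups match in atom count and carry only halogen or methyl substitution, and no measured compound shows the effect of such a swap on the sulfonyl aryl; the expected step is a number 5 percentage points lower from compound 3 to compound 4 (within the scatter), that is no change beyond the scatter, with a slight lean downward as a hedge.

Compound 4 is therefore expected to give about 80% in this assay, within a range of 60% to 95%.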

Compound 4, a percentage reported as inhibition, at one concentration (the size of the read-out at that concentration, not a potency): 94%
Estimate against measurement, compound 4: 14 percentage points below; low and high end bracket the measured number.
By their numbers in this assay, from the lowest: compound 1; then compounds 3, 2 and 4 (each within the scatter of the next).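

In this assay, among the compounds shown here, the swap of 3-fluoro-4-methylphenyl for 3-chloro-4-fluorophenyl on a sulfonyl sulfur gives the first measured single-place step: a number 9 percentage points higher from compound 3 to compound 4 (within the scatter). This position therefore accepts this change of aryl substitution without a shift beyond the scatter, and both compounds keep a high read-out, though that rests on this one pair alone. Nothing measured on these compounds bears on why the two aryl groups read alike.

From the compounds shown here alone, whether the sulfonyl aryl would hold the read-out with a carboxylic acid or an amine in place of these halogen and methyl substituents stays open. Each reading is also from a single concentration, so it gives no potency and leaves compound 3 and compound 4 unranked.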